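Swapping the chlorophenyl arm of compound 3 for an oxygenated ring

The source may report more compounds than this note shows. Statements on the series, on what has been measured and on what is new or still open speak of the compounds shown alone.

Measured compounds:
compound 1, `COc1cccc(/C=C2\CCC/C(=C\c3cccc(Cl)c3)C2=O)c1OC`, 10300 nM
compound 2, `COc1cccc(/C=C2\CCC/C(=C\c3ccc(O)c(O)c3)C2=O)c1OC`, 4700 nM
compound 3, `COc1ccc(/C=C2\CCC/C(=C\c3cccc(Cl)c3)C2=O)cc1OC`, 4900 nM

In a functional assay on HT-1080 cells (Homo sapiens) for cytotoxicity, read by MTT assay, with a stated time of 72 h (on this read-out higher numbers stand for weaker inhibition and lower numbers for stronger inhibition), compound 3 gives 4900 nM, the second highest of the three numbers. Its nearest neighbour is compound 2, which it matches within the scatter; compound 1, with 10300 nM, stands furthest away, beyond the scatter.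

The unmeasured compound 4, `COc1cc(/C=C2\CCC/C(=C\c3ccc(OC)c(OC)c3)C2=O)ccc1O`, differs from compound 3 in one place: 4-hydroxy-3-methoxyphenyl in place of 3-chlorophenyl on a double-bonded chain carbon bound to a double-bonded ring carbon.

Going by the values given here, one measured step bears on this change. From compound 1 to compound 2 the same 3-chlorophenyl gave way to an oxygenated ring, and that step read a 2.2-fold lower number from compound 1 to compound 2 (0.34 log units; beyond the scatter). The change from compound 3 to compound 4 likewise replaces 3-chlorophenyl by a ring bearing oxygen, though the entering group here carries one hydroxy and one methoxy rather than two hydroxy groups. A modest lowering of the number is therefore expected, of about the same size or a little smaller, giving a 1.8-fold lower number from compound 3 to compound 4 (0.24 log units; within the scatter) as the expected step.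

On that basis compound 4 is estimated at 2800 nM, with a range from 1200 nM to 6500 nM.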

Compound 4, half-maximal inhibitory concentration: 4600 nM
Compound 4: the middle estimate sits 1.6-fold (0.22 log units) below what was measured; the range from low to high includes it.
By their numbers in this assay, from the lowest: compounds 4, 2 and 3 (each within the scatter of the next); then compound 1.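

In this assay, 4-hydroxy-3-methoxyphenyl in place of 3-chlorophenyl gave a 1.1-fold lower number from compound 3 to compound 4 (0.03 log units; within the scatter), so on this core the exchange produced no change that can be told from the scatter. The earlier exchange of 3-chlorophenyl for an oxygen-bearing ring, a 2.2-fold lower number from compound 1 to compound 2 (0.34 log units; beyond the scatter), lay beyond the scatter, which shows that such a swap at this place does not lower the number in both pairs shown; the two pairs differ in the entering ring and in the other arm of the core. Nothing available here accounts for the contrast between the two steps.

From the compounds shown here alone, whether that contrast follows the entering ring or the other arm of the core remains open. Also open, going by these compounds, is how a ring bearing an amine or a carboxylic acid would read at this place in this assay.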